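Swapping trifluoromethyl for ethyl on compound 1

A few compounds are considered here, and "the series" means these few. Any claim that something is new, unique, unknown or untested is made for them only; others in the source may bear on it.

Among the compounds with values here, compound 1 `Cc1ccnc(NC(c2ccc(C(F)(F)F)cc2)c2ccc3cccnc3c2O)c1` gives the highest of the three numbers so far in an assay for inhibition of protein disulfide-isomerase (Homo sapiens), with a stated time of 1 h (on this read-out higher numbers stand for weaker inhibition and lower numbers for stronger inhibition), at 26500 nM. Compound 2 `Oc1c(C(Nc2ccccn2)c2c(Cl)cccc2Cl)ccc2cccnc12` gives 1890 nM, and compound 3 `Cc1cc(C)c(C(Nc2ccccn2)c2ccc3cccnc3c2O)c(C)c1` gives 190 nM. Within the data shown here, the one single-point comparison among them is a 9.9-fold lower number from compound 2 to compound 3 (1.00 log units; beyond the scatter), with 2,4,6-trimethylphenyl in place of 2,6-dichlorophenyl on a saturated chain carbon bound to an aromatic carbon and a nitrogen on an aromatic ring.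

Compound 4 `CCc1ccc(C(Nc2cc(C)ccn2)c2ccc3cccnc3c2O)cc1` differs from compound 1 at a different place: ethyl in place of trifluoromethyl on an aromatic carbon. Among the measured compounds shown here, no measured step touches that group, so the comparison of compound 2 with compound 3 offers only indirect guidance, in that it concerns the same pendant phenyl ring but another substitution pattern. Compound 4 is therefore expected to land a 1.9-fold lower number from compound 1 to compound 4 (0.28 log units; within the scatter), a step likely small and uncertain in direction. The estimate for compound 4 in this assay is 14000 nM, with a range from 3500 nM to 56000 nM.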

Compound 4, half-maximal inhibitory concentration: 5390 nM
Compound 4: middle estimate off by 2.6-fold (0.41 log units), on the high side; low and high end bracket the measured number.
By their numbers in this assay, from the lowest: compound 3; then compound 2; then compound 4; then compound 1.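

In this assay, the change from 4-(trifluoromethyl)phenyl to 4-ethylphenyl gives a 4.9-fold lower number from compound 1 to compound 4 (0.69 log units; beyond the scatter), so the group on this aromatic carbon, para to a large group, moves the number beyond the usual scatter. Within the data shown here, the only earlier step, a 9.9-fold lower number from compound 2 to compound 3 (1.00 log units; beyond the scatter), involved a different substitution pattern on the ring and did not isolate this position. Here, the lower number comes with ethyl, which has fewer heavy atoms than trifluoromethyl, but no measurement shown explains the step.

With only these two groups compared at this position, the compounds shown leave open whether a methyl, a longer chain such as propyl, or a methoxy group would lower the number further. They also leave open whether the step would keep its size on a core without the methyl group that compound 1 and compound 4 share.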